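Swapping Bromo for Methoxy on Compound 2

The source may hold more compounds than are shown below. What is called first, only, known or untested is meant among the compounds shown, and "the series" means these compounds.

In an ADME assay on HEK293 cells (Homo sapiens) for cytotoxicity, read by MTT assay, with a stated time of 24 h (on this read-out higher numbers stand for weaker inhibition and lower numbers for stronger inhibition), two compounds have been measured so far. Compound 1 (`CN1CCN(CCCNc2nc3cc([N+](=O)[O-])ccc3nc2NCc2ccc(C(F)(F)F)cc2)CC1`) gives 9.53 ug/mL, and compound 2 (`CN(C)CCCNc1nc2cc([N+](=O)[O-])ccc2nc1NCc1ccc(Br)cc1`) gives 9.63 ug/mL, so the two stand level within the usual scatter of repeated measurements. Compound 3 (`COc1ccc(CNc2nc3ccc([N+](=O)[O-])cc3nc2NCCCN(C)C)cc1`) has not yet been measured in this assay. It is compound 2 with methoxy in place of bromo on an aromatic carbon, para to a large group, which turns the 4-bromobenzyl into 4-methoxybenzyl: methoxy in place of bromo on an aromatic carbon. Among the measured compounds shown here, no measured pair differs in one place only, so nothing here shows directly what this swap does. For the measured compounds named here, the only guide is the narrow spread of the two numbers, with compound 1 at 9.53 ug/mL and compound 2 at 9.63 ug/mL. On that slim evidence, no change beyond the scatter is expected, and the estimated step of a 1.0-fold higher number from compound 2 to compound 3 (0.02 log units; within the scatter) is small, in no firm direction. Compound 3 is expected at about 10 ug/mL, with an estimated range from 4.5 ug/mL to 20 ug/mL.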

Compound 3, half-maximal inhibitory concentration: 38.6 ug/mL
Beside the measured number, compound 3's estimate is 3.9-fold (0.59 log units) below it, outside the stated range (above it).
By their numbers in this assay, from the lowest: compounds 1 and 2 (each within the scatter of the next); then compound 3.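

Among the compounds shown here, this is the first pair that differs in one place only, and it shows that the aromatic carbon para to a large group is not indifferent to what it carries. In this assay, going from 4-bromobenzyl to 4-methoxybenzyl gives a 4.0-fold higher number from compound 2 to compound 3 (0.60 log units; beyond the scatter) and so means weaker inhibition, with a swap of only one heavy atom for two moving the number beyond the scatter. Nothing available explains why the number rises.

On these data alone, whether this rise is particular to methoxy, or would also follow other groups at the same place, such as an amine, a nitrile or a carboxylic acid, remains open. Also open, as far as these compounds go, is whether a step of this size would appear with the different side chain of compound 1, since a single pair cannot show how far the effect of this swap carries over to other compounds.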